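The source may report more compounds than this note shows. Statements on the series, on what has been measured and on what is new or still open speak of the compounds shown alone.

Measured compounds in this series:
compound 1 `CC(C)(C)OC(=O)N1CCC(O[C@H]2CC[C@H](Oc3ccc(S(C)(=O)=O)cc3)CC2)CC1` — in a functional assay on isolated protein for agonist activity at Glucose-dependent insulinotropic receptor (Homo sapiens), read by HTRF and cAMP accumulation (on this read-out lower numbers stand for an effect already at smaller amounts and higher numbers for an effect only at larger amounts of compound), compound 1 gives 16.1 nM
compound 2 `CC(C)(C)OC(=O)N1CCC(O[C@H]2CC[C@H](Oc3ccc(C#N)cc3)CC2)CC1` — compound 2 gives 8.6 nM
compound 3 `CC(C)(C)OC(=O)N1CCC(O[C@H]2CC[C@H](Oc3cnc(S(C)(=O)=O)cn3)CC2)CC1` — compound 3 gives 5.9 nM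

Compound 3 stands apart from compound 1 by a 2.7-fold lower number from compound 1 to compound 3 (0.44 log units; beyond the scatter), whereas compound 2 and compound 3 lie within the scatter of each other, a 1.5-fold lower number from compound 2 to compound 3 (0.16 log units; within the scatter). The remaining step, a 1.9-fold lower number from compound 1 to compound 2 (0.27 log units; within the scatter), is also within the scatter.

Compound 4 `CC(C)S(=O)(=O)c1cnc(O[C@H]2CC[C@H](OC3CCN(C(=O)OC(C)(C)C)CC3)CC2)cn1` differs from compound 3 in one place: isopropyl in place of methyl on a sulfonyl sulfur. Going by the values given here, none of the measured steps touches the substituent on the sulfonyl sulfur: the step from compound 1 to compound 2 removes the whole methylsulfonyl group for a nitrile, and the two steps leading to compound 3 alter the aromatic ring that carries it. Among the compounds with values here, there is therefore no direct precedent in this assay for a change on the sulfonyl carbon chain, and the change itself is small in atom count. The step from compound 3 to compound 4 is expected to stay within the scatter, a 1.1-fold higher number from compound 3 to compound 4 (0.04 log units; within the scatter), with no clear direction. Compound 4 is accordingly estimated at 6.5 nM in this assay, with a range from 2.5 nM to 17 nM.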

Compound 4, half-maximal effective concentration: 18.5 nM
The estimate for compound 4 lay 2.8-fold (0.45 log units) below the measured number; the measured number lies above the stated range.
By their numbers in this assay, from the lowest: compounds 3, 2, 1 and 4 (each within the scatter of the next, the first and the last beyond it).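

In this assay the substituent on the sulfonyl sulfur is not a silent place: isopropyl in place of methyl gives a step beyond the scatter (a 3.1-fold higher number from compound 3 to compound 4 (0.50 log units; beyond the scatter)), the only step shown at this place. The change is small, 3 heavy atoms entering for 1, with no hydrogen-bond donors or acceptors and no net charge on either side, so a purely carbon change at this place is enough to raise the number. No measurement at hand gives a reason for this rise.

Going by these compounds, whether the rise follows the size of the group or its branching stays open; ethyl, n-propyl and cyclopropyl on the sulfonyl sulfur would separate the two. Also open, on these data alone, are the reading for an amine on that sulfur, giving a sulfonamide, and whether isopropylsulfonyl acts alike on the aromatic ring of compound 1.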